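The source may report more compounds than this note shows. Statements on the series, on what has been measured and on what is new or still open speak of the compounds shown alone.

In an ADME assay on Huh-7 cells (Homo sapiens) for cytotoxicity (on this read-out higher numbers stand for lower toxicity in this test and lower numbers for higher toxicity in this test), compound 1 `Cc1ncnc2c1c(Cl)cn2[C@@H]1C=C(CO)[C@@H](O)[C@H]1O` gives > 100000 nM, which is a limit of the test rather than a number. Compound 2 `Cc1ncnc2c1c(I)cn2[C@@H]1C=C(CO)[C@@H](O)[C@H]1O` gives > 100000 nM in this assay, again a limit and not a number. The step that the two limits leave unreadable from compound 1 to compound 2 is therefore not readable in size, since (the limit of > 100000 nM in this assay, at which 2 of the 2 values shown sit). Compound 3 `C#Cc1cn([C@@H]2C=C(CO)[C@@H](O)[C@H]2O)c2ncnc(C)c12` differs from compound 2 by ethynyl in place of iodo on an aromatic carbon. Going by the values given here, the only measured step in this assay, a step that the two limits leave unreadable from compound 1 to compound 2, bears on this change in that it also exchanges one substituent for another on an aromatic carbon, but the two limits hide how large it was, so no measured step gives a size to carry over. Nothing among the measurements shows toxicity for compound 1 or compound 2 within the concentrations the test covers, and the step of a number no higher from compound 2 to compound 3 (the limit leaves the size open) is expected to be none beyond the scatter. Compound 3 is accordingly estimated at 100000 nM in this assay, with a range from 30000 nM to 300000 nM, and most likely only a limit will again be reported.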

Compound 3, half-maximal cytotoxic concentration: > 100000 nM
Compound 3: only a limit was reported (the forecaster's own chance of this, stated with the estimate: 80%); the middle value lies on the limit itself.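

In this assay compound 3 gives > 100000 nM, again a limit and not a number. No step among compound 1, compound 2 and compound 3 can therefore be read: the limit of > 100000 nM in this assay, at which 3 of the 3 values shown sit.

The compounds shown leave open whether chloro, iodo and ethynyl on the shared core differ at all in this assay.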